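Working notes: from compound 2 to compound 3

The source may report more compounds than this note shows. Statements on the series, on what has been measured and on what is new or still open speak of the compounds shown alone.

Measured in an in vivo ADME assay on the whole organism (Cavia porcellus); on this read-out higher numbers stand for a longer-lived compound and lower numbers for a shorter-lived compound:
- compound 1 `CC(C)(C(=O)N1CCC(CC(=O)O)CC1)C(NC(=O)c1ccc(C(=N)N)cc1)c1ccc(Cl)cc1`: 1.2 h
- compound 2 `CCOC(=O)CC1CCN(C(=O)C(C)(C)C(CC)NC(=O)c2ccc(C(=N)N3CCCC3)cc2F)CC1`: 2.07 h

Among the compounds with values here, compound 2, at 2.07 h, stands within the usual scatter of compound 1, the only other measured compound, at 1.2 h. These two compounds differ in more than one place, so no measured step sizes the change considered here.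

Compound 3 `CCOC(=O)CC1CCN(C(=O)C(C)(C)C(CC)NC(=O)c2ccc(C(=N)N3CCN(C)CC3)cc2F)CC1` differs from compound 2 as follows: 4-methylpiperazin-1-yl in place of pyrrolidin-1-yl on a carbon with a double bond to nitrogen. In words, it has 4-methylpiperazin-1-yl in place of pyrrolidin-1-yl on a carbon with a double bond to nitrogen.

No change beyond the scatter is expected in this assay, and neither direction is favoured. The expected change is a 1.2-fold lower number from compound 2 to compound 3 (0.06 log units; within the scatter). Within the data shown here, the estimate rests on compound 2 at 2.07 h, with a wide range because no matched step is available. For compound 3 the expected value is 1.8 h, with an estimated range of 0.9 h to 3.6 h.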

Compound 3, half-life: 1.77 h
The estimate for compound 3 lay 1.0-fold (0.01 log units) above the measured number; the measured number falls inside the stated range.
By their numbers in this assay, from the lowest: compounds 1, 3 and 2 (each within the scatter of the next).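

In this assay, within the data shown here, 4-methylpiperazin-1-yl in place of pyrrolidin-1-yl on a carbon with a double bond to nitrogen gives a 1.2-fold lower number from compound 2 to compound 3 (0.07 log units; within the scatter), the first matched step. This position therefore takes a six-membered ring with a second ring nitrogen and a hydrogen-bond acceptor, and the number stays within the scatter of that of the five-membered ring. Nothing measured alongside this step speaks to the reason for the result.

Still open, on these data alone, is whether this tolerance extends to morpholin-4-yl, with an oxygen in the ring, or to an open-chain dimethylamino group on the same carbon. The compounds shown also leave open whether the step keeps its size when a free carboxylic acid replaces the ethyl ester.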